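Replacing 5-(hydroxycarbamoyl)pentyl with (hydroxycarbamoyl)methoxy

A few compounds are considered here, and "the series" means these few. Any claim that something is new, unique, unknown or untested is made for them only; others in the source may bear on it.

In a functional assay on ES2 cells (Homo sapiens) for inhibition, read by MTT assay, with a stated time of 48 h (a lower number here means a stronger inhibitor, a higher number a weaker inhibitor), compound 1 `O=C(CCCCOc1no[n+]([O-])c1S(=O)(=O)c1ccccc1)NO` gives 2530 nM, compound 2 `O=C(CCCCCCOc1no[n+]([O-])c1S(=O)(=O)c1ccccc1)NO` gives 7730 nM and compound 3 `O=C(CCCCCCCOc1no[n+]([O-])c1S(=O)(=O)c1ccccc1)NO` gives 1320 nM. Compound 3 has the lowest of these numbers, but its lead over compound 1 is not real: a 1.9-fold lower number from compound 1 to compound 3 (0.28 log units; within the scatter) stays within the scatter. Only compound 2 stands clearly apart from it, as a 5.9-fold lower number from compound 2 to compound 3 (0.77 log units; beyond the scatter) shows.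

Compound 4 `O=C(COCCOc1no[n+]([O-])c1S(=O)(=O)c1ccccc1)NO` carries (hydroxycarbamoyl)methoxy in place of 5-(hydroxycarbamoyl)pentyl on a saturated chain carbon, two bonds along the chain from an oxygen on an aromatic ring.

Among the compounds with values here, no measured step makes this exchange. The three measured compounds differ only in the length of the saturated chain, and the numbers do not follow that length in one direction: a 3.1-fold higher number from compound 1 to compound 2 (0.49 log units; beyond the scatter) goes up, and the further lengthening to compound 3 brings the number back down. These steps therefore give only a rough size, modest at most, and no firm direction. Since compound 3 sits with compound 1 at the low end of the series, a modest rise seems the likelier outcome. The expected change is a 2.3-fold higher number from compound 3 to compound 4 (0.36 log units; beyond the scatter). For compound 4 the estimated value is 3000 nM, with an expected range of 1000 nM to 9000 nM.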

Compound 4, half-maximal inhibitory concentration: 8690 nM
The estimate for compound 4 lay 2.9-fold (0.46 log units) below the measured number; the measured number falls inside the stated range.
By their numbers in this assay, from the lowest: compounds 3 and 1 (each within the scatter of the next); then compounds 2 and 4 (each within the scatter of the next).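

In this assay, within the data shown here, compound 4 is the first with an oxygen inside the chain, and this exchange does not keep the number at the low end: a 6.6-fold higher number from compound 3 to compound 4 (0.82 log units; beyond the scatter) and a 3.4-fold higher number from compound 1 to compound 4 (0.54 log units; beyond the scatter) both lie beyond the scatter. Against compound 2 the picture differs, as a 1.1-fold higher number from compound 2 to compound 4 (0.05 log units; within the scatter) stays within the scatter, so a (hydroxycarbamoyl)methoxy chain and an all-carbon chain can end up level at this position, and high numbers in the series are not tied to one kind of chain. Nothing available here explains the rise from compound 3 to compound 4.

The compounds shown leave open whether that rise goes with the oxygen in the chain or with the smaller group, as (hydroxycarbamoyl)methoxy differs from 5-(hydroxycarbamoyl)pentyl in both respects at once. They also leave open how a longer chain carrying the same oxygen, an amine at that place in the chain, or a carboxylic acid in place of the hydroxycarbamoyl end would read in this assay at this position.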